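This account rests on a few compounds, and the source may have more. Where it says the series, first, only, none or still open, it means among the compounds named here.

In a functional assay on HEK293 cells for antagonist activity at transient receptor potential cation channel subfamily V member 1 (Rattus norvegicus), read by calcium flux (on this read-out lower numbers stand for stronger inhibition and higher numbers for weaker inhibition), compound 3 `FC(F)(F)c1ccc(Nc2nc(N3CCC3)nc3sc(Nc4c(Cl)cccc4Cl)nc23)cc1` gives 25 nM, which places it second highest among the three numbers recorded. Its nearest neighbour is compound 2 `Cc1nc(Nc2ccc(C(F)(F)F)c(Cl)c2)c2nc(Nc3c(Cl)cccc3Cl)sc2n1`, which gives 2 nM in this assay, a number well beyond the scatter below it; furthest away is compound 1 `CN(c1nc2c(Nc3ccc(C(F)(F)F)cc3)ncnc2s1)c1c(Cl)cccc1Cl`, which gives 540 nM, a number well beyond the scatter above it.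

Compound 4 `CC(C)CNc1nc(Nc2ccc(C(F)(F)F)cc2)c2nc(Nc3c(Cl)cccc3Cl)sc2n1` differs from compound 3 in one place: isobutylamino in place of azetidin-1-yl on an aromatic carbon. For the measured compounds named here, no pair of measured compounds shows this exact change, so the step has to be judged from the spread seen so far. Compound 2 carries a small group at the same position and gives 2 nM, while compound 3 with its azetidin-1-yl group gives 25 nM; both sit far from compound 1. On that basis the change from compound 3 to compound 4 is expected to be modest, most likely a small move towards a lower number, with a 2.1-fold lower number from compound 3 to compound 4 (0.32 log units; beyond the scatter) as the expected step. Compound 4 is therefore estimated at 12 nM, with a range from 3 nM to 50 nM.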

Compound 4, half-maximal inhibitory concentration: 1 nM
Beside the measured number, compound 4's estimate is 12-fold (1.08 log units) above it, and the stated range ends above it.
By their numbers in this assay, from the lowest: compounds 4 and 2 (each within the scatter of the next); then compound 3; then compound 1.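

In this assay, for the compounds shown here, replacing azetidin-1-yl with isobutylamino on the aromatic carbon between two ring nitrogen atoms gives a 25-fold lower number from compound 3 to compound 4 (1.40 log units; beyond the scatter), a large step and the first direct reading of a single change. Going by these compounds alone, it shows that the number depends strongly on the group at this position, which the earlier compounds, differing in more than one place, could not show. The change removes the four-membered ring and brings in an open chain and a hydrogen-bond donor together, and nothing available here accounts for the size of the step.

As far as these compounds go, it remains open whether the ring loss, the nitrogen hydrogen or the branched chain carries the step, which pyrrolidin-1-yl, dimethylamino or methylamino at this position could help separate. From the compounds shown here alone, how a longer chain or a terminal carboxylic acid would fare here is also open.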